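The compounds below may be only part of what the source reports. "The series", "measured", "known", "first", "only" and "open" are said of these compounds alone.

Three compounds of one series have been run in an assay on cells for antagonist activity at transient receptor potential cation channel subfamily V member 1 (Homo sapiens), read by FLIPR and calcium flux, with a stated time of 6 min; on this read-out lower numbers stand for stronger inhibition and higher numbers for weaker inhibition. Compound 1 `CCCCN(C)c1nc(C(C)(C)C)ccc1CNC(=O)C(C)c1ccc(NS(C)(=O)=O)c(F)c1` gives 1.2 nM. Compound 2 `CC(C(=O)NCc1ccc(C(C)(C)C)nc1OCc1ccccc1)c1ccc(NS(C)(=O)=O)c(F)c1` gives 4.4 nM, which is a 3.7-fold higher number from compound 1 to compound 2 (0.56 log units; beyond the scatter). Compound 3 `CC(C(=O)NCc1ccc(C(C)(C)C)nc1SCCCN(C)C)c1ccc(NS(C)(=O)=O)c(F)c1` gives 51.8 nM, the highest of the three numbers: it stands a 43-fold higher number from compound 1 to compound 3 (1.64 log units; beyond the scatter) and a 12-fold higher number from compound 2 to compound 3 (1.07 log units; beyond the scatter). So compound 3, with its (3-(dimethylamino)propyl)sulfanyl group on the shared core, is the weakest inhibitor among the measured compounds.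

Compound 4 `CC(C(=O)NCc1ccc(C(C)(C)C)nc1SCc1ccccc1Cl)c1ccc(NS(C)(=O)=O)c(F)c1` keeps the sulfur link but changes what hangs on it: 2-chlorophenyl in place of 2-(dimethylamino)ethyl on a saturated chain carbon bound to a sulfur. Read one bond further out, (3-(dimethylamino)propyl)sulfanyl becomes (2-chlorobenzyl)sulfanyl, which brings the substituent close in shape to the benzyloxy group of compound 2.

Going by the values given here, the steps that bear on this change are a 12-fold higher number from compound 2 to compound 3 (1.07 log units; beyond the scatter) and a 43-fold higher number from compound 1 to compound 3 (1.64 log units; beyond the scatter); both say that the chain with the dimethylamino end carries the poorest number. Removing it in favour of a benzyl-type group is therefore expected to move the number back down in this assay, by a step of roughly an 8.6-fold lower number from compound 3 to compound 4 (0.94 log units; beyond the scatter), toward the region of compound 2. Compound 4 is thus estimated at 6 nM, within a range from 2 nM to 25 nM.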

Compound 4, inhibition constant: 3.8 nM
Beside the measured number, compound 4's estimate is 1.6-fold (0.20 log units) above it; the range from low to high includes it.
By their numbers in this assay, from the lowest: compound 1; then compounds 4 and 2 (each within the scatter of the next); then compound 3.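

In this assay, the sulfur link alone does not account for a poor number: with the link kept, 2-chlorophenyl in place of 2-(dimethylamino)ethyl on a saturated chain carbon bound to a sulfur gives a 14-fold lower number from compound 3 to compound 4 (1.13 log units; beyond the scatter), so among these sulfur-linked compounds the poor number goes with the dimethylamino chain. Putting (2-chlorobenzyl)sulfanyl in place of benzyloxy on an aromatic carbon gives a 1.2-fold lower number from compound 2 to compound 4 (0.06 log units; within the scatter), so the two benzyl-type groups are not told apart here, although this step changes the linking atom and adds the chlorine together. The butyl(methyl)amino group still keeps its advantage over this new group, with a 3.2-fold higher number from compound 1 to compound 4 (0.50 log units; beyond the scatter).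

No measurement shown here accounts for these differences in terms of cause. From the compounds shown here alone, what stays open is whether the chlorine matters at all, which a plain benzyl group on the sulfur would test, and whether the dimethylamino end lowers the inhibition wherever it stands, which a 3-(dimethylamino)propyl group on oxygen or a plain butyl chain on the sulfur would test.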